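Swapping the Iodophenyl Amide Substituent for Difluorophenyl

The source may hold more compounds than are shown below. What is called first, only, known or untested is meant among the compounds shown, and "the series" means these compounds.

Measured compounds:
- compound 1, `O=C(Nc1ccc(I)cc1)c1cncc(N2CC3CC(C2)N3)c1`: 103 nM
- compound 2, `COc1cc(NC(=O)c2cncc(N3CC4CC(C3)N4)c2)cc(OC)c1`: 2000 nM
- compound 3, `COc1ccc(NC(=O)c2cncc(N3CC4CC(C3)N4)c2)cc1OC`: 516 nM

All three compounds share a core that carries an amide, and they differ only in the aromatic ring attached to the amide nitrogen. In an assay on cells for displacement of a labelled ligand from Neuronal acetylcholine receptor; alpha3/beta4 (Homo sapiens) (on this read-out higher numbers stand for weaker inhibition and lower numbers for stronger inhibition), compound 1 gives 103 nM and stands as the strongest of the three, since its distance to compound 3 and to compound 2 is beyond the usual scatter. Compound 2 and compound 3 each carry two methoxy groups on that ring and give higher numbers in this assay.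

Compound 4, `O=C(Nc1ccc(F)cc1F)c1cncc(N2CC3CC(C2)N3)c1`, has not yet been measured. Compared with compound 1 it has 2,4-difluorophenyl in place of 4-iodophenyl on an amide-type nitrogen. For the measured compounds named here, no pair of measured compounds shows this exact change, so no direct step is available. Going by the values given here, the halogen pattern changes in kind and in count, and the only related comparisons with compounds 2 and 3 point to weaker binding when the ring is altered. A moderate weakening is therefore expected, with the step from a 2.9-fold higher number from compound 1 to compound 4 (0.46 log units; beyond the scatter) as the estimate. Compound 4 is expected to give about 300 nM in this assay, within a range from 80 nM to 1200 nM.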

Compound 4, inhibition constant: 50 nM
The estimate for compound 4 lay 6.0-fold (0.78 log units) above the measured number, and the stated range ends above it.
By their numbers in this assay, from the lowest: compound 4; then compound 1; then compound 3; then compound 2.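

In this assay, the change to 2,4-difluorophenyl on the amide nitrogen gives a 2.1-fold lower number from compound 1 to compound 4 (0.31 log units; beyond the scatter), a modest step but one beyond the usual scatter. This shows that the iodine of the 4-iodophenyl group is not needed for binding, and that a change to this ring can also lower the number, whereas the dimethoxy rings of compound 2 and compound 3 had shown only higher numbers than compound 1. Nothing available explains why this swap lowers the number.

The swap changes both the kind of halogen and how many the ring carries, and a single-halogen ring such as 4-fluorophenyl or 4-chlorophenyl would be needed to separate the two. Going by these compounds, how a ring carrying an amine, or a non-aromatic group such as cyclohexyl, would behave on this nitrogen also remains open.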